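A few compounds are considered here, and "the series" means these few. Any claim that something is new, unique, unknown or untested is made for them only; others in the source may bear on it.

Compound 1 `COc1cc(OC)c(/C=C(/SCc2ccc(F)cc2)C(=O)c2ccc(Br)cc2)c(OC)c1`: 1000 nM
Compound 2 `O=C(/C(=C\c1cc(Cl)c(O)c(Cl)c1)SCc1ccc(Br)cc1)c1ccc(Br)cc1`: 10000 nM
Compound 3 `O=C(/C(=C\c1ccc(F)cc1C(F)(F)F)[S+]([O-])Cc1ccc(Cl)cc1)c1ccc(Cl)cc1`: 50000 nM

In a functional assay on DU-145 cells (Homo sapiens) for inhibition, read by trypan blue exclusion, with a stated time of 96 h (on this read-out higher numbers stand for weaker inhibition of growth and lower numbers for stronger inhibition of growth), compound 3 has the highest number of the three, at 50000 nM, and so the weakest growth inhibition. Compound 4 `Cc1ccc(CS/C(=C/c2ccc(F)cc2C(F)(F)F)C(=O)c2ccc(Cl)cc2)cc1` differs from it by one change, (a group of 9 heavy atoms (8 carbon, 1 sulfur; one six-membered aromatic ring of carbon only) in place of a group of 10 heavy atoms (7 carbon, 1 oxygen, 1 sulfur, 1 chlorine; one six-membered aromatic ring of carbon only), on a double-bonded chain carbon bound to a carbonyl carbon and a double-bonded chain carbon), with (4-methylbenzyl)sulfanyl as the entering group. Going by the values given here, no measured pair shows this change directly. Like compound 4, compound 1 at 1000 nM and compound 2 at 10000 nM have no oxygen on their sulfur, though they differ from it elsewhere too. A drop beyond the scatter is therefore expected, and the estimated change is a 5.0-fold lower number from compound 3 to compound 4 (0.70 log units; beyond the scatter). For compound 4 the estimated value is 10000 nM, with an expected range from 2500 nM to 40000 nM.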

Compound 4, concentration for 50% growth inhibition: 50000 nM
The estimate for compound 4 lay 5.0-fold (0.70 log units) below the measured number; measured number above the stated range.
By their numbers in this assay, from the lowest: compound 1; then compound 2; then compounds 3 and 4 (each within the scatter of the next).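

Going by these compounds alone, the step of no change at the digits printed from compound 3 to compound 4 (within the scatter) in this assay is the first one-place comparison. At the double-bonded chain carbon bound to a carbonyl carbon and a double-bonded chain carbon, (4-methylbenzyl)sulfanyl takes the place of a group carrying oxygen on sulfur and chlorine, and growth inhibition stays level. Nothing available accounts for this result. The pair cannot separate the loss of the oxygen from the loss of the chlorine, since both leave together. Going by these compounds, how an amine or a carboxylic acid on this benzyl group would read remains open.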